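A few compounds are considered here, and "the series" means these few. Any claim that something is new, unique, unknown or untested is made for them only; others in the source may bear on it.

Measured in a physicochemical assay for lipophilicity, measured as octanol-water partition, at pH 7.4; a lower number here means a more polar compound, a higher number a more lipophilic compound:
Compound 1 `N#Cc1ccc(N[C@H]2CC[C@H](N(C(=O)NCc3ccccc3)c3ccc(-c4cccnc4)cc3)CC2)nc1`: 3
Compound 2 `Cn1cccc(-c2ccc(N(C(=O)NCc3ccccc3)[C@H]3CC[C@H](Nc4ccc(C#N)cn4)CC3)cc2)c1=O`: 2.7

Among the measured compounds shown here, compound 2 stands within the scatter of compound 1, the only other compound with a number, so the two cannot be ranked. Compound 3 `Cn1c(-c2ccc(N(C(=O)NCc3ccccc3)[C@H]3CC[C@H](Nc4ccc(C#N)cn4)CC3)cc2)cccc1=O` has not yet been measured. It keeps the rest of compound 2 and exchanges one group for another made of the same atoms, joined differently: a group of 8 heavy atoms (6 carbon, 1 nitrogen, 1 oxygen; one six-membered aromatic ring with 1 hetero atom) in place of a group of 8 heavy atoms (6 carbon, 1 nitrogen, 1 oxygen; one six-membered aromatic ring with 1 hetero atom), on an aromatic carbon. For the measured compounds named here, one measured step bears on this, a number 0.30 log units lower from compound 1 to compound 2 (within the scatter), which also exchanged a group on an aromatic carbon. That exchange changed the size of the group and still stayed within the scatter. The present exchange, with no change in atoms, is therefore not expected to shift this assay beyond the scatter, and no direction can be favoured. The expected step is a number 0.10 log units lower from compound 2 to compound 3 (within the scatter). Compound 3 is estimated at 2.6, with an expected range from 2.1 to 3.1.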

Compound 3, distribution coefficient: 2.6
Estimate against measurement, compound 3: no gap at the digits printed; measured number inside the range.
By their numbers in this assay, from the lowest: compounds 3, 2 and 1 (each within the scatter of the next, the first and the last beyond it).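

In this assay, the exchange on the aromatic carbon para to a large group gave a number 0.10 log units lower from compound 2 to compound 3 (within the scatter), so joining the same atoms differently produced no readable shift at this position. Putting this group in place of the group of 6 heavy atoms gave a number 0.40 log units lower from compound 1 to compound 3 (beyond the scatter), a modest step and the first at this position to pass the scatter, whereas the other replacement gave a number 0.30 log units lower from compound 1 to compound 2 (within the scatter). Nothing measured here accounts for either step.

The compounds shown leave open how this position responds to a different kind of group, such as an amine or a carboxylic acid, as all three carry a six-membered aromatic ring with 1 hetero atom there. As far as these compounds go, whether the exchange between the two groups of the same atoms would stay within the scatter on an altered core also remains open.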